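This account rests on a few compounds, and the source may have more. Where it says the series, first, only, none or still open, it means among the compounds named here.

Three analogues of the shared core have been run in a functional assay on CHO cells for agonist activity at Melanocortin receptor 4 (Homo sapiens), read by cAMP accumulation; on this read-out lower numbers stand for smaller maximal responses and higher numbers for larger maximal responses. Compound 1 `CC[C@H](NC(C)=O)c1cc(Cl)ccc1C1CCN(C(=O)[C@@H]2CN(C(C)(C)C)C[C@H]2c2ccc(F)cc2F)CC1` gives 108%; compound 2 `CC[C@H](NC(C)=O)c1cc(Cl)ccc1C1CCN(C(=O)[C@@H]2CN(C(C)(C)C)C[C@H]2c2ccc(Cl)cc2Cl)CC1` gives 48%; compound 3 `CC[C@H](NC(C)=O)c1cc(Cl)ccc1C1CCN(C(=O)[C@@H]2CN(C(C)(C)C)C[C@H]2c2ccc(Cl)cc2F)CC1` gives 97%. Compound 3 stands second highest of the three, sitting a number 11 percentage points lower from compound 1 to compound 3 (beyond the scatter) and a number 49 percentage points higher from compound 2 to compound 3 (beyond the scatter). The remaining pair shows a number 60 percentage points lower from compound 1 to compound 2 (beyond the scatter).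

Compound 4 `CC[C@H](NC(C)=O)c1cc(Cl)ccc1C1CCN(C(=O)[C@@H]2CN(C(C)(C)C)C[C@H]2c2ccc(C(F)(F)F)cc2F)CC1` is not yet measured. The change from compound 3 is trifluoromethyl in place of chloro on an aromatic carbon, on an aromatic carbon of a six-membered aromatic ring of carbon only. Among the compounds with values here, the steps that bear on it are those at the same aromatic carbon: swapping fluoro for chloro there cost a modest amount, a number 11 percentage points lower from compound 1 to compound 3 (beyond the scatter), while the reverse gain, a number 49 percentage points higher from compound 2 to compound 3 (beyond the scatter), was large only with the second halogen also changed. Trifluoromethyl is a larger substituent than chloro, so a further loss of maximal response is the expectation, of the order of a modest to moderate step downward in this assay, though a result within the scatter of compound 3 cannot be ruled out.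

Compound 4 is therefore expected to give about 82% in this assay, within 55% to 105%, an expected step of a number 15 percentage points lower from compound 3 to compound 4 (beyond the scatter).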

Compound 4, largest response reached (reported as percent of maximum), in percent of the reference or control that the assay uses: 99%
For compound 4 the middle estimate is 17 percentage points below the measured one, and the stated range covers the measured number.
By their numbers in this assay, from the lowest: compound 2; then compounds 3, 4 and 1 (each within the scatter of the next, the first and the last beyond it).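

With the fluoro group on the same ring unchanged, trifluoromethyl (4 heavy atoms) in place of chloro (1 heavy atom) on this aromatic carbon gives, in this assay, a number 2 percentage points higher from compound 3 to compound 4 (within the scatter). Trifluoromethyl in place of fluoro at this carbon likewise gives a number 9 percentage points lower from compound 1 to compound 4 (within the scatter), so this position accepts the largest of the three groups seen there without a step beyond the scatter. The large step, a number 51 percentage points higher from compound 2 to compound 4 (beyond the scatter), shows that the low response of compound 2 does not follow from the heavy-atom count at this carbon alone.

Nothing at hand gives a cause for these steps. Open, going by these compounds, is whether a nitrile, an amine, a carboxylic acid or a longer chain on this aromatic carbon would keep the response seen with trifluoromethyl.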